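Cytotoxicity of a New Analogue Judged From Three Limits

The compounds below may be only part of what the source reports. "The series", "measured", "known", "first", "only" and "open" are said of these compounds alone.

Compound 1 `COC(=O)c1cc(-c2cccc(NC(=O)c3ccc(C4OC4C(=O)c4ccc(Cl)cc4)cc3)c2)on1` gives > 20 ug/mL in an ADME assay on Vero cells (Chlorocebus sabaeus) for cytotoxicity, read by MTT assay, with a stated time of 72 h; on this read-out higher numbers stand for lower toxicity in this test and lower numbers for higher toxicity in this test. That value is a limit of this assay, not a number.
Compound 2 `COC(=O)c1cc(-c2cccc(NC(=O)c3ccc(OCc4ccc(Cl)cc4)cc3)c2)on1` gives > 80 ug/mL in this assay. That value is a limit.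
Compound 3 `COC(=O)c1cc(-c2cccc(NC(=O)c3ccc(/C=C/C(=O)c4ccccc4Br)cc3)c2)on1` gives > 40 ug/mL in this assay. That value is a limit.

Compound 1 therefore stands only at a limit, as do the two other measured compounds, sitting at the limit of > 20 ug/mL in this assay, at which 1 of the 3 values shown sits, the limit of > 40 ug/mL in this assay, at which 1 of the 3 values shown sits, and (the limit of > 80 ug/mL in this assay, at which 1 of the 3 values shown sits). Compound 4 `COC(=O)c1cc(-c2cccc(NC(=O)c3ccc(/C=C/C(=O)c4ccc(Br)cc4)cc3)c2)on1` differs from compound 1 by 2-((4-bromophenyl)carbonyl)ethenyl in place of 3-((4-chlorophenyl)carbonyl)oxiran-2-yl on an aromatic carbon. The nearest measured steps are a step that the two limits leave unreadable from compound 1 to compound 3 and a step that the two limits leave unreadable from compound 1 to compound 2; neither can be read in size, so no step beyond the scatter is expected in this assay. Compound 4 is expected to give 40 ug/mL (range 15 ug/mL to 100 ug/mL), an expected step that the limit leaves unreadable from compound 1 to compound 4.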

Compound 4, half-maximal cytotoxic concentration: > 20 ug/mL
Compound 4: a limit, no number; the forecaster's own chance of this, stated with the estimate: 75%; the middle value does not contradict the limit.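

Compound 4 also stands only at a limit in this assay, so its steps from compound 1, compound 2 and compound 3 cannot be read in size. The compounds shown leave open whether their toxicities differ at all.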